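Aryl swap at the chain carbon: compound 3 to compound 4

A few compounds are considered here, and "the series" means these few. Any claim that something is new, unique, unknown or untested is made for them only; others in the source may bear on it.

Compound 3 `Cc1cn2cc(C[C@H](C)CN3C[C@@H]4CCCC[C@@H]4[C@H](C(=O)N4CCN(c5ccc(F)c(F)c5)CC4)C3)ccc2n1` stands lowest of the three numbers in an assay on isolated protein for binding affinity to somatostatin receptor type 1 (Homo sapiens); on this read-out lower numbers stand for tighter binding and higher numbers for weaker binding: compound 3 gives 39.8 nM, compound 1 `COC(=O)c1cc(C[C@@H](C)CN2C[C@@H]3CCCC[C@@H]3[C@H](C(=O)N3CCN(c4ccc([N+](=O)[O-])cc4)CC3)C2)cc(C(=O)OC)c1` gives 437 nM and compound 2 `Cc1nc2cc(C[C@H](C)CN3C[C@@H]4CCCC[C@@H]4[C@H](C(=O)N4CCN(c5ccc(F)c(F)c5)CC4)C3)ccc2o1` gives 1380 nM, and both gaps to compound 3 are beyond the scatter. The move to compound 4 `CCNc1ccc(C[C@H](C)CN2C[C@@H]3CCCC[C@@H]3[C@H](C(=O)N3CCN(c4ccc(F)c(F)c4)CC3)C2)cn1` is a group of 9 heavy atoms (7 carbon, 2 nitrogen; one six-membered aromatic ring with 1 hetero atom) in place of a group of 10 heavy atoms (8 carbon, 2 nitrogen; one five-membered aromatic ring with 2 hetero atoms, one six-membered aromatic ring with 1 hetero atom), on a saturated chain carbon, three bonds along the chain from an amine nitrogen in a ring. Going by the values given here, only one measured step touches the same place: a 35-fold lower number from compound 2 to compound 3 (1.54 log units; beyond the scatter), which shows that a swap here can move the read-out widely. Among the compounds with values here, no measured step shows the entering group itself. Because the only replacement at this place moved the number by a 35-fold lower number from compound 2 to compound 3 (1.54 log units; beyond the scatter), a sizable shift is expected, taken as a rise toward the other two values. Compound 4 is therefore estimated at 150 nM, range 40 nM to 600 nM. The expected step is a 3.8-fold higher number from compound 3 to compound 4 (0.58 log units; beyond the scatter).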

Compound 4, dissociation constant: 1910 nM
For compound 4 the middle estimate is 13-fold (1.10 log units) below the measured one; measured number above the stated range.
By their numbers in this assay, from the lowest: compound 3; then compound 1; then compounds 2 and 4 (each within the scatter of the next).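

In this assay, the saturated chain carbon gives a second large step (a 48-fold higher number from compound 3 to compound 4 (1.68 log units; beyond the scatter)), so the low number of compound 3 does not carry over to 6-(ethylamino)pyridin-3-yl. Against 2-methyl-1,3-benzoxazol-5-yl, the same group gives no separation (a 1.4-fold higher number from compound 2 to compound 4 (0.14 log units; within the scatter)), leaving the group of compound 3 alone at the low end among these three. No supporting measurement bears on the reason for this result.

Whether the ethylamino chain or the pyridine ring accounts for the gap stays open. A plain pyridin-3-yl, or a propyl chain in place of the ethyl on the amine, would help separate the two.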